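Removing the amide-linked chain: isothiocyanate placed directly on the ring

The source may hold more compounds than are shown below. What is called first, only, known or untested is meant among the compounds shown, and "the series" means these compounds.

Compound 1 `CN(C)C(=O)c1cc2cnc(Nc3ccc(C(=O)NCCCCN=C=S)cc3)nc2n1C1CCCC1` stands highest of the three numbers in a functional assay on A549 cells (Homo sapiens) for inhibition, read by CCK-8 assay, with a stated time of 72 h, tested at 10 uM; a higher number here means a stronger effect of the compound at the concentration tested, a lower number a weaker effect: compound 1 gives 102%, compound 2 `CN(C)C(=O)c1cc2cnc(Nc3ccc(C(=O)NCCCCCCCN=C=S)cc3)nc2n1C1CCCC1` gives 101%, and compound 3 `CN(C)C(=O)c1cc2cnc(Nc3ccc(C(=O)NCCCCN=C=S)cc3F)nc2n1C1CCCC1` gives 24.4%. The lengthening of the chain is a number 1 percentage points lower from compound 1 to compound 2 (within the scatter); the fluoro is a number 77.6 percentage points lower from compound 1 to compound 3 (beyond the scatter). Compound 4 `CN(C)C(=O)c1cc2cnc(Nc3ccc(N=C=S)cc3)nc2n1C1CCCC1` differs from compound 1 by a group of 3 heavy atoms (1 carbon, 1 nitrogen, 1 sulfur; no ring) in place of a group of 10 heavy atoms (6 carbon, 2 nitrogen, 1 oxygen, 1 sulfur; no ring), on an aromatic carbon, placed on an aromatic carbon of a six-membered ring, para to a large group. Among the compounds with values here, neither measured step touches this linker region, so no step bears directly on it. The isothiocyanate is kept in compound 4, and both chain lengths held the effect, so a moderate drop with wide uncertainty is expected: compound 4 is estimated at 75%, range 25% to 105%, a step of a number 27 percentage points lower from compound 1 to compound 4 (beyond the scatter) expected.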

Compound 4, a percentage reported as inhibition, at one concentration (the size of the read-out at that concentration, not a potency): 97.9%
Beside the measured number, compound 4's estimate is 22.9 percentage points below it, within the range that was stated.
By their numbers in this assay, from the lowest: compound 3; then compounds 4, 2 and 1 (each within the scatter of the next).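

In this assay, the bare isothiocyanate on the aromatic carbon, in place of the whole amide-linked chain, gives a number 4.1 percentage points lower from compound 1 to compound 4 (within the scatter). The earlier compounds shown here varied only the chain length; here, the amide and chain together can go without the read-out moving beyond the scatter at this single concentration. Nothing available explains why the effect persists without them.

Open, going by these compounds, is whether the effect depends on the isothiocyanate, which an amine on the same aromatic carbon would test. Also open, on these data alone, is whether fluoro lowers the number on compound 4 as it does on compound 1.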